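Capping the Terminal Amine of a Coumarin Amide

The source may hold more compounds than are shown below. What is called first, only, known or untested is meant among the compounds shown, and "the series" means these compounds.

Of the compounds shown here, three sharing one core have been measured in a functional assay on the whole organism (strain Fisher 344) for inhibition, with Rattus norvegicus as the target, read by paw edema, with a stated time of 3.5 h, at a dose of 0.01 mmol/kg by the intraperitoneal route; on this read-out higher numbers stand for more inhibition at the one dose given (going by the name of the read-out) and lower numbers for less inhibition. Compound 1 `Cc1ccc2oc(=O)c(C(=O)Nc3ccccc3N)c(O)c2c1` gives 60% in this assay, compound 3 `NCCNC(=O)c1c(O)c2ccccc2oc1=O` gives 59%, and compound 2 `NCCCCCCCCNC(=O)c1c(O)c2ccccc2oc1=O` gives 48%. Going by the values given here, compound 2 thus stands lowest of the three numbers: its nearest neighbour is compound 3, and the only single-point step in the set, a number 11 percentage points higher from compound 2 to compound 3 (beyond the scatter), concerns amino in place of 6-aminohexyl on a saturated chain carbon, two bonds along the chain from an amide-type nitrogen. Compound 1 lies furthest from compound 2, also beyond the scatter.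

Compound 4 `O=C(CCCCC1CCSS1)NCCCCCCCCNC(=O)c1c(O)c2ccccc2oc1=O` departs from compound 2 at a different place. The change is a group of 11 heavy atoms (8 carbon, 1 oxygen, 2 sulfur; one five-membered non-aromatic ring with 2 hetero atoms) in place of a hydrogen atom, on an amine nitrogen, on an amine nitrogen whose other neighbour is a saturated chain carbon. Among the compounds with values here, no measured step touches this nitrogen; the one step known shortens the chain rather than substituting the amine, so it bears on compound 4 only loosely, and it showed a modest gain when the chain was removed. Within the data shown here, with no direct precedent, the expected step of a number 2 percentage points higher from compound 2 to compound 4 (within the scatter) is estimated to stay within the scatter. Compound 4 is therefore estimated at 50% in this assay, with a range from 30% to 70%.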

Compound 4, a percentage reported as inhibition, in the whole organism at one dose (the size of the read-out at that dose, not a potency): 43%
For compound 4 the middle estimate is 7 percentage points above the measured one, within the range that was stated.
By their numbers in this assay, from the lowest: compounds 4 and 2 (each within the scatter of the next); then compounds 3 and 1 (each within the scatter of the next).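

Going by these compounds alone, on the amine nitrogen whose other neighbour is a saturated chain carbon, the step of a number 5 percentage points lower from compound 2 to compound 4 (within the scatter) in this assay gives the first direct reading at this place, which the earlier step along the chain could not supply. It shows that replacing the hydrogen atom with a group of 11 heavy atoms, including one five-membered non-aromatic ring with 2 hetero atoms, leaves the read-out within the scatter, so at this one dose the free amine of compound 2 is not shown to be needed for the inhibition of paw edema. No measurement shown here offers an explanation for this result.

Going by these compounds, what remains open is whether the sulfur atoms or the ring play any part, since a smaller acetyl group or a plain hexanoyl chain on the same nitrogen would separate the ring from the carbonyl that links it. On these data alone, it also remains open whether the same group would leave the read-out unchanged on the shorter chain of compound 3, and whether a carboxylic acid at the chain end would behave like the capped amine.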